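Moving the hydroxyl arm around the phenyl ring

This account rests on a few compounds, and the source may have more. Where it says the series, first, only, none or still open, it means among the compounds named here.

Of the compounds shown here, three have been measured in an assay for inhibition of 15-hydroxyprostaglandin dehydrogenase [NAD(+)] (Homo sapiens), read by fluorescence, with a stated time of 15 min, in the presence of a further agent that is not named here; a lower number here means a stronger inhibitor, a higher number a weaker inhibitor. Compound 1 `CCC[S+]([O-])c1sc2nc(-c3cccs3)cc(C(=O)O)c2c1N` gives 71 nM in this assay. Compound 2 `CCCC[S+]([O-])c1nc2ccc(-c3cccs3)nc2s1` gives 1230 nM. Compound 3 `CCCC[S+]([O-])c1sc2nc(-c3nccs3)cc(-c3cccc(CO)c3)c2c1N` gives 4.3 nM, the lowest of the three numbers; its gap to compound 1 and its wider gap to compound 2 both lie beyond the usual scatter, so compound 3 is the strongest inhibitor of the measured set. Compound 4 `CCCC[S+]([O-])c1sc2nc(-c3nccs3)cc(-c3ccc(CCO)cc3)c2c1N` has not yet been measured. It differs from compound 3 in a single place: 4-(2-hydroxyethyl)phenyl in place of 3-(hydroxymethyl)phenyl on an aromatic carbon. The phenyl ring and its hydroxyl-bearing arm are kept; the arm grows by one carbon and moves around the ring. Within the data shown here, no pair of measured compounds shows this kind of change, so there is no measured step to lean on. The step of a 1.9-fold higher number from compound 3 to compound 4 (0.27 log units; within the scatter) is expected to be small, at most a modest weakening, and likely within the scatter. Compound 4 is therefore expected to give about 8 nM in this assay, with a range from 2.5 nM to 25 nM.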

Compound 4, half-maximal inhibitory concentration: 2.9 nM
Compound 4: the middle estimate sits 2.8-fold (0.44 log units) above what was measured; low and high end bracket the measured number.
By their numbers in this assay, from the lowest: compounds 4 and 3 (each within the scatter of the next); then compound 1; then compound 2.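

In this assay, among these compounds, replacing 3-(hydroxymethyl)phenyl with 4-(2-hydroxyethyl)phenyl gives a 1.5-fold lower number from compound 3 to compound 4 (0.17 log units; within the scatter), the only measured step in this set that alters a single place. It shows that, at the aromatic carbon opposite the ring nitrogen, the potency seen with compound 3 does not depend on this exact arm: a hydroxyl-bearing arm with one more carbon, set elsewhere on the phenyl ring, reads the same within the scatter. Nothing available explains why the two arms read alike.

Because the arm grew and moved in one step, the compounds shown cannot separate length from ring placement, which 4-(hydroxymethyl)phenyl could help resolve. They also leave open whether the hydroxyl is needed at all, or whether an amine or a carboxylic acid at the end of the arm would serve equally.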